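Fluoro for hydrogen on the aryl ring of compound 3

The compounds below may be only part of what the source reports. "The series", "measured", "known", "first", "only" and "open" are said of these compounds alone.

Compound 3 `O=C(CN1CCCCC1)N1N=C(c2ccccc2)CC1c1ccccc1O` gives 9510 nM in an assay on isolated protein for inhibition of Amine oxidase [flavin-containing] A (Homo sapiens), read by fluorescence, with stated times of 15 min and 20 min; on this read-out higher numbers stand for weaker inhibition and lower numbers for stronger inhibition. Going by the values given here, it stands second highest of the three numbers measured so far: its nearest neighbour is compound 2 `Cc1ccc(C2=NN(C(=O)CN3CCCCC3)C(c3ccccc3O)C2)cc1` with 11300 nM, and the furthest is compound 1 `O=C(CBr)N1N=C(c2ccc(F)cc2)CC1c1ccccc1O` with 6000 nM; both gaps lie within the scatter. Among the compounds with values here, the one single-point step measured, a 1.2-fold lower number from compound 2 to compound 3 (0.07 log units; within the scatter), is a change on the same aryl ring and stays within the scatter.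

Compound 4 `O=C(CN1CCCCC1)N1N=C(c2ccc(F)cc2)CC1c1ccccc1O` differs from compound 3 by fluoro in place of hydrogen on an aromatic carbon. Within the data shown here, the step from compound 2 to compound 3 is the only measured change at that ring and was flat. Compound 1 also carries the 4-fluorophenyl, but it differs from compound 3 in a second place as well, so its value only shows that the two numbers sit within the scatter of each other. Nothing seen here points to a shift beyond the scatter in this assay in either direction. The expected step is a 1.1-fold lower number from compound 3 to compound 4 (0.05 log units; within the scatter), no movement beyond the scatter. Compound 4 is estimated at 8500 nM, with a range of 4000 nM to 18000 nM.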

Compound 4, half-maximal inhibitory concentration: 8020 nM
Estimate against measurement, compound 4: 1.1-fold (0.03 log units) above; the range from low to high includes it.
By their numbers in this assay, from the lowest: compounds 1, 4, 3 and 2 (each within the scatter of the next).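

In this assay, phenyl to 4-fluorophenyl gives a 1.2-fold lower number from compound 3 to compound 4 (0.07 log units; within the scatter), so this ring position shows no response to fluoro in place of hydrogen. With a 1.4-fold lower number from compound 2 to compound 4 (0.15 log units; within the scatter), fluoro and methyl at this same aromatic carbon are not told apart either, and hydrogen, methyl and fluoro now all read as level there. Going by these compounds alone, the first single-place reading at the saturated chain carbon bound to the carbonyl carbon is a 1.3-fold higher number from compound 1 to compound 4 (0.13 log units; within the scatter), so piperidin-1-yl and bromo are also not told apart at that second place.

As far as these compounds go, whether a carboxylic acid or an amine on the aromatic ring, or a longer chain in place of the piperidin-1-yl, would move the number beyond the scatter remains open. No measured evidence is available to account for these level readings.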